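Sulfonamide benzothiadiazine series: removing a chloro from the sulfonyl aryl

A few compounds are considered here, and "the series" means these few. Any claim that something is new, unique, unknown or untested is made for them only; others in the source may bear on it.

Measured so far:
compound 1 `CCOC(=O)c1cc2c(cc1Cl)SC(N(c1ccc(OC)cc1)S(=O)(=O)c1ccc(Cl)cc1Cl)=NS2(=O)=O` gives 6300 nM
compound 2 `O=C(Oc1cccc2cccnc12)c1cc2c(cc1Cl)SC(N(c1ccc(F)cc1)S(=O)(=O)c1ccc(Cl)cc1)=NS2(=O)=O` gives > 20000 nM
compound 3 `CCOC(=O)c1cc2c(cc1Cl)SC(N(c1ccc(F)cc1)S(=O)(=O)c1ccc(OC)cc1)=NS2(=O)=O` gives 19000 nM

All three share one core and differ in the ester, the aryl on the sulfonamide nitrogen and the sulfonyl aryl. In a functional assay on RT-4 cells (Homo sapiens) for cytotoxicity, with a stated time of 96 h (on this read-out lower numbers stand for stronger inhibition of growth and higher numbers for weaker inhibition of growth), compound 1 gives the lowest of the two numbers shown. Compound 3, which carries a 4-fluorophenyl on the nitrogen and a 4-methoxyphenylsulfonyl, gives 19000 nM, a gap that lies beyond the scatter. Compound 2 reaches only (the limit of > 20000 nM in this assay, at which 1 of the 3 values shown sits), so for compound 2 the value is a limit and not a number. Going by the values given here, no pair of measured compounds differs in a single place, so no measured step can be drawn.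

Compound 4 `CCOC(=O)c1cc2c(cc1Cl)SC(N(c1ccc(OC)cc1)S(=O)(=O)c1ccc(Cl)cc1)=NS2(=O)=O` is compound 1 with one change: hydrogen in place of chloro on an aromatic carbon. The two weaker compounds both lack the 2,4-dichlorophenyl, but they differ from compound 1 elsewhere as well, so the contribution of the chloro alone cannot be read from them. The expectation is a modest loss, a 1.9-fold higher number from compound 1 to compound 4 (0.28 log units; within the scatter), beyond the scatter but far short of the limit seen for compound 2. Compound 4 is therefore estimated at 12000 nM, with a likely range from 5000 nM to 30000 nM.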

Compound 4, concentration for 50% growth inhibition: 23100 nM
Compound 4: the middle estimate sits 1.9-fold (0.28 log units) below what was measured; low and high end bracket the measured number.
By their numbers in this assay, from the lowest: compound 1; then compounds 3 and 4 (each within the scatter of the next).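

Going by these compounds alone, replacing chloro with hydrogen on the sulfonyl aryl, at the carbon ortho to a large group and meta to a chloro group, gives a 3.7-fold higher number from compound 1 to compound 4 (0.56 log units; beyond the scatter) in this assay, the only single-place comparison so far. With the ethyl ester, the aryl on the sulfonamide nitrogen and the 4-chloro all held constant, this step isolates a contribution from this one chloro to growth inhibition, which compounds 1, 2 and 3 could not do because they differ in several places at once. Nothing shown gives a cause for this step.

On these data alone, whether the step carries over to a compound with the 4-fluorophenyl on the nitrogen, or to one with a different ester, remains open. Also open, as far as these compounds go, is how other groups on this same carbon, such as methyl, methoxy or an amine, would compare with chloro and hydrogen, and whether removing the remaining chloro from the 4-chlorophenyl would change the number further.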